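The source may report more compounds than this note shows. Statements on the series, on what has been measured and on what is new or still open speak of the compounds shown alone.

Measured so far in an ADME assay (MDM cells, Homo sapiens) for cytotoxicity, read by resazurin assay, with a stated time of 3 days; a higher number here means a weaker inhibitor, a lower number a stronger inhibitor:
compound 1, `CSc1nnc(COc2ccccc2C2=NOC(c3ccc(Cl)cc3Cl)C2)n1NC(=O)CCl`, gives 2.7 ug/mL;
compound 2, `CCCSc1nnc(COc2ccccc2C2=NOC(c3ccc(Cl)cc3Cl)C2)n1NC(=O)CCl`, gives 28.7 ug/mL;
compound 3, `CCCCSc1nnc(COc2ccccc2C2=NOC(c3ccc(Cl)cc3Cl)C2)n1NC(=O)c1ccccc1`, gives 2.5 ug/mL.

From compound 2 to compound 1 the change is hydrogen in place of ethyl on a saturated chain carbon bound to a sulfur, and it produced an 11-fold lower number from compound 2 to compound 1 (1.03 log units; beyond the scatter). Compound 4, `CCSc1nnc(COc2ccccc2C2=NOC(c3ccc(Cl)cc3Cl)C2)n1NC(=O)c1ccccc1`, is not yet measured; it differs from compound 3 by hydrogen in place of ethyl on a saturated chain carbon, two bonds along the chain from a sulfur. This is the same kind of change, but the place is not identical: in the earlier pair the carbon is bound to a sulfur, here it lies two bonds along the chain from a sulfur. The difference between the two cores of compound 2 and compound 3 is not broken down here. In this assay compound 3 stands within the scatter of compound 1. For compound 4 a step of a 2.1-fold lower number from compound 3 to compound 4 (0.32 log units; beyond the scatter) is expected, smaller than the earlier one, resting on an 11-fold lower number from compound 2 to compound 1 (1.03 log units; beyond the scatter) while the place and core differ. Compound 4 is estimated at 1.2 ug/mL, between 0.3 ug/mL and 5 ug/mL.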

Compound 4, half-maximal inhibitory concentration: 1.8 ug/mL
The estimate for compound 4 lay 1.5-fold (0.18 log units) below the measured number; measured number inside the range.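

On the core of compound 3, putting hydrogen in place of ethyl gave a 1.4-fold lower number from compound 3 to compound 4 (0.14 log units; within the scatter), so in this assay this step cannot be told apart from the ordinary spread of repeated measurements. Within the data shown here, the same kind of change therefore did not carry over with the same size from one core to the other: the same change on two cores in this assay, an 11-fold lower number (1.03 log units; beyond the scatter) from compound 2 to compound 1 and a 1.4-fold lower number (0.14 log units; within the scatter) from compound 3 to compound 4, 7.7-fold (0.88 log units) apart, beyond the scatter of two such steps With only two pairs, which also differ in where the change sits, this does not show whether the core or the place accounts for the gap, nor what a third core would do.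

The compounds shown leave open how a chain longer than butyl on the sulfur would read in this assay. They also leave open what an amine or a carboxylic acid at the end of that chain would do.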